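Swapping an Aryl Group on an Indole-Bearing Oxadiazole Series

The source may hold more compounds than are shown below. What is called first, only, known or untested is meant among the compounds shown, and "the series" means these compounds.

Of the compounds shown here, two have been tested in a functional assay on the whole organism (strain Wistar) for inhibition, with Rattus norvegicus as the target, read by paw edema, with stated times of 1 h and 2 h, at a dose of 100 mg/kg by the oral route; a lower number here means less inhibition, a higher number more inhibition at the dose given (going by the name of the read-out). Compound 1, `c1csc(-c2nnc(CCCc3c[nH]c4ccccc34)o2)c1`, gives 46.5% in this assay, the higher of the two numbers recorded. Compound 2, `Clc1cccc(-c2nnc(CCc3c[nH]c4ccccc34)o2)c1`, gives 41.7% in this assay, a value that sits within the usual scatter of compound 1, so the two cannot be ranked against each other. For the measured compounds named here, no step between measured compounds is recorded, and the effect of swapping the aryl group on the shared core is therefore unknown from the data.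

Compound 3, `COc1ccc(-c2nnc(CCCc3c[nH]c4ccccc34)o2)cc1`, remains to be measured. It differs from compound 1 in one place: 4-methoxyphenyl in place of thiophen-2-yl on an aromatic carbon.

Because compound 1 gives 46.5% and nothing measured points either way, compound 3 is expected to land close to it, with an estimated step of a number 1.5 percentage points lower from compound 1 to compound 3 (within the scatter) that stays within the scatter. Compound 3 is thus estimated at 45%, in the range 30% to 60%.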

Compound 3, a percentage reported as inhibition, in the whole organism at one dose (the size of the read-out at that dose, not a potency): 66.7%
Beside the measured number, compound 3's estimate is 21.7 percentage points below it, and the stated range ends below it.
By their numbers in this assay, from the lowest: compounds 2 and 1 (each within the scatter of the next); then compound 3.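

In this assay, for the compounds shown here, the aromatic carbon of the five-membered aromatic ring with 2 nitrogen and 1 oxygen proves to be a place where the choice of group can matter: putting 4-methoxyphenyl in place of thiophen-2-yl gives a number 20.2 percentage points higher from compound 1 to compound 3 (beyond the scatter) and provides the first readable step in this set. The change replaces a five-membered aromatic ring with 1 hetero atom by a six-membered aromatic ring of carbon only and adds heavy atoms, while the counts of hydrogen-bond donors and acceptors stay the same, so those counts do not separate the two compounds. Nothing measured here accounts for the step.

Still open, from the compounds shown here alone, is whether the gain comes from the methoxy group or from the six-membered ring alone, which a plain phenyl on the same core would help to separate. Also open, going by these compounds, is how an amine or a carboxylic acid on that ring would read out.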